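Working notes: hydroxy to methoxy on the shared core

The source may report more compounds than this note shows. Statements on the series, on what has been measured and on what is new or still open speak of the compounds shown alone.

In an ADME assay on MT4 cells (Homo sapiens) for cytotoxicity, read by spectrophotometry, with a stated time of 5 days (on this read-out higher numbers stand for lower toxicity in this test and lower numbers for higher toxicity in this test), compound 2 `Cc1ccc2c(c1)/C(=N/NC(=S)NO)C(=O)N2CN1CCN(c2ccccc2)CC1` gives 420000 nM. Compound 1 `CONC(=S)N/N=C1\C(=O)N(CN2CCN(c3ccc(Cl)cc3)CC2)c2ccc(C)cc21` gives 300000 nM in this assay. For the measured compounds named here, these are the only two measured values, and they lie within the scatter of each other, so compound 2 stands level with compound 1 on present data.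

Compound 3 `CONC(=S)N/N=C1\C(=O)N(CN2CCN(c3ccccc3)CC2)c2ccc(C)cc21` is still unmeasured. It follows from compound 2 by one structural change, methyl in place of hydrogen on an oxygen, which turns hydroxyamino into methoxyamino.

Going by the values given here, no measured pair differs in one place only, so the size of this change in this assay has no direct precedent. Among the compounds with values here, the only guide is how close the two measured values are, with compound 1 at 300000 nM and compound 2 at 420000 nM. No step beyond the scatter is expected, and no firm direction can be given. The expected step is a 1.2-fold lower number from compound 2 to compound 3 (0.08 log units; within the scatter), and it is expected to stay within the scatter. The estimated value for compound 3 is 350000 nM, with an expected range of 180000 nM to 620000 nM.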

Compound 3, half-maximal cytotoxic concentration: 276000 nM
The estimate for compound 3 lay 1.3-fold (0.10 log units) above the measured number; the range from low to high includes it.
By their numbers in this assay, from the lowest: compounds 3, 1 and 2 (each within the scatter of the next).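

In this assay, methyl in place of hydrogen on an oxygen whose other neighbour is an amide-type nitrogen, which turns hydroxyamino into methoxyamino, now has a direct reading: a 1.5-fold lower number from compound 2 to compound 3 (0.18 log units; within the scatter) and so stays within the scatter. Compound 3 also gives the series a second single-place pair, hydrogen in place of chloro on an aromatic carbon, which reads a 1.1-fold lower number from compound 1 to compound 3 (0.04 log units; within the scatter) and likewise stays within the scatter, so neither change can be told apart from repeat variation in this read-out. No measurement on hand bears on these two results, and no cause can be assigned to either of them.

The compounds shown leave open whether a longer chain on that oxygen, such as ethyl or benzyl, or an amine in place of the methoxyamino group, would give a step beyond the scatter. They also leave open whether a group other than chloro or hydrogen on that aromatic carbon, such as a carboxylic acid, would do so in this assay.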